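The compounds below may be only part of what the source reports. "The series", "measured", "known", "first", "only" and "open" are said of these compounds alone.

Of the compounds shown here, three built on one shared core have so far been measured in an assay on isolated protein for inhibition of DNA topoisomerase 1 (Homo sapiens), with a stated time of 30 min, tested at 100 uM; on this read-out higher numbers stand for a stronger effect at the one concentration tested and lower numbers for a weaker effect. Compound 1, `Oc1ccc(-c2cc(-c3ccccc3)nc(-c3ccccc3Cl)c2)cc1`, gives 13.6% and stands highest of the three numbers. Compound 3, `Oc1cccc(-c2cc(-c3ccccc3)nc(-c3ccccc3Cl)c2)c1`, gives 3.2%, and compound 2, `Oc1cccc(-c2cc(-c3cccc(Cl)c3)nc(-c3ccccn3)c2)c1`, gives 0.4%. Among the measured compounds shown here, the one single-place step among them is a number 10.4 percentage points lower from compound 1 to compound 3 (beyond the scatter), a modest drop in which 3-hydroxyphenyl takes the place of 4-hydroxyphenyl on an aromatic carbon.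

Compound 4, `Oc1ccc(-c2cc(-c3cccnc3)nc(-c3ccccc3Cl)c2)cc1`, has not yet been measured in this assay. It differs from compound 1 by pyridin-3-yl in place of phenyl on an aromatic carbon. For the measured compounds named here, no measured step bears directly on this change: the step from compound 1 to compound 3 alters the hydroxyphenyl group and leaves the phenyl untouched, and compound 2 differs from compound 1 in more than one place, so its value shows only that a compound on this core can sit near zero. With nothing of direct relevance, the account expects a step in this assay that is small, most likely within the scatter, perhaps leaning downward because compound 3 gives 3.2% and compound 2 gives 0.4%. For compound 4 the estimated value is 9%, with a range from 0% to 25%. That corresponds to an expected step of a number 4.6 percentage points lower from compound 1 to compound 4 (within the scatter).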

Compound 4, a percentage reported as inhibition, at one concentration (the size of the read-out at that concentration, not a potency): 0.9%
Compound 4: the middle estimate sits 8.1 percentage points above what was measured; the range from low to high includes it.
By their numbers in this assay, from the lowest: compounds 2, 4 and 3 (each within the scatter of the next); then compound 1.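

In this assay, among the compounds shown here, this is the first direct reading at the position next to the ring nitrogen, and it shows that the position is not indifferent to the change: putting a ring nitrogen into the phenyl group, to give pyridin-3-yl, brings a number 12.7 percentage points lower from compound 1 to compound 4 (beyond the scatter). Together with a number 10.4 percentage points lower from compound 1 to compound 3 (beyond the scatter), which alters the 4-hydroxyphenyl group instead, this means that both single-place changes shown for compound 1 lower the number, each beyond the scatter, although these two compounds alone cannot establish a wider pattern. Nothing available explains why pyridin-3-yl gives a lower number than phenyl here.

As far as these compounds go, it remains open whether the drop belongs to a ring nitrogen in general or to its particular placement in pyridin-3-yl, which pyridin-2-yl and pyridin-4-yl at the same position could separate. From the compounds shown here alone, it is also open whether this position can raise the number at all, for example with a phenyl group carrying an amine, a methoxy group or a carboxylic acid.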